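Imidazoline anilines: an oxime ether in place of oxazole

This account rests on a few compounds, and the source may have more. Where it says the series, first, only, none or still open, it means among the compounds named here.

Measured compounds:
compound 1, `Cc1ncc(-c2ccccc2NCC2=NCCN2)o1` — < 5020 nM
compound 2, `c1csc(-c2ccccc2NCC2=NCCN2)c1` — 5.75 nM
compound 3, `CC/C(=N\OC)c1ccccc1NCC1=NCCN1` — < 100000 nM

In a functional assay for activation of Alpha-1B adrenergic receptor (Homo sapiens), read by calcium flux (a lower number here means that less compound is needed, a higher number that more compound is needed for the effect), compound 1 gives only a limit, < 5020 nM, so its place among the three cannot be fixed; the limit is the one described as the limit of < 5020 nM in this assay, at which 1 of the 3 values shown sits. Compound 2 gives a number in this assay, 5.75 nM. Compound 3 gives only a limit in this assay, < 100000 nM, the one described as the limit of < 100000 nM in this assay, at which 1 of the 3 values shown sits. All three measured steps are unreadable: a step that the limit leaves unreadable from compound 1 to compound 2, a step that the two limits leave unreadable from compound 1 to compound 3 and a step that the limit leaves unreadable from compound 2 to compound 3.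

Compound 4, `CO/N=C/c1ccccc1NCC1=NCCN1`, differs from compound 1 by a group of 4 heavy atoms (2 carbon, 1 nitrogen, 1 oxygen; no ring) in place of a group of 6 heavy atoms (4 carbon, 1 nitrogen, 1 oxygen; one five-membered aromatic ring with 2 hetero atoms), on an aromatic carbon. Among the compounds with values here, the step that bears most on it is the one from compound 1 to compound 3, which also exchanges the oxazole for an oxime ether, yet its size is not readable, so no size or direction can be taken from the measured steps. The estimate for compound 4 in this assay is 500 nM, with a range from 50 nM to 5000 nM. The step this estimate means is expected to be a step that the limit leaves unreadable from compound 1 to compound 4, and a further limit rather than a number remains a real possibility.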

Compound 4, half-maximal effective concentration: < 5020 nM
Compound 4: no number, only a limit; the forecaster's own chance of this, stated with the estimate: 30%; the middle value lies beyond the limit too.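

In this assay compound 4 gives < 5020 nM, a limit and not a number. The steps from compound 1, compound 2 and compound 3 to compound 4 cannot be read. Still open, on these data alone, is where compound 4 truly stands in this assay, and whether it differs from compound 1 or compound 3 at all.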